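Notes on the aryl group of the series

The source may report more compounds than this note shows. Statements on the series, on what has been measured and on what is new or still open speak of the compounds shown alone.

Measured so far in a physicochemical assay for solubility; on this read-out higher numbers stand for higher solubility and lower numbers for lower solubility:
- Compound 1 `COc1ccc(-n2cnc3cnc(-c4ccccc4)cc32)cc1OC` gives 28000 nM
- Compound 2 `COc1ccc(-n2cnc3cnc(-c4ccccc4C)cc32)cc1OC` gives > 200000 nM as a limit of the assay
- Compound 3 `COc1ccc(-n2cnc3cnc(-c4ccc(F)cc4OC)cc32)cc1OC` gives 42000 nM

Compound 3 stands level with compound 1, the gap being a 1.5-fold higher number from compound 1 to compound 3 (0.18 log units; within the scatter). Compound 2 sits at the limit of > 200000 nM in this assay, at which 1 of the 3 values shown sits.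

The next structure, compound 4 `COc1ccc(-n2cnc3cnc(-c4cc(F)ccc4C)cc32)cc1OC`, has 5-fluoro-2-methylphenyl in place of 4-fluoro-2-methoxyphenyl on an aromatic carbon.

Going by the values given here, two measured steps bear on this change: an at least 7.1-fold higher number from compound 1 to compound 2 (0.85 log units; beyond the scatter) and, closest to it, an at least 4.7-fold lower number from compound 2 to compound 3 (0.67 log units; beyond the scatter). Both are open-ended. Among the compounds with values here, compound 4 keeps the methyl of compound 2 and the fluorine of compound 3, and no measured step separates the two. A reversal of only part of an at least 4.7-fold lower number from compound 2 to compound 3 (0.67 log units; beyond the scatter) is therefore expected, giving a higher number in this assay. The estimated step is a 2.6-fold higher number from compound 3 to compound 4 (0.42 log units; beyond the scatter). The estimate for compound 4 is 110000 nM within an expected range from 40000 nM to 250000 nM.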

Compound 4, solubility: 157000 nM
The estimate for compound 4 lay 1.4-fold (0.15 log units) below the measured number; the range from low to high includes it.
By their numbers in this assay, from the lowest: compounds 1 and 3 (each within the scatter of the next); then compound 4. At a limit, above all of these: compound 2.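

In this assay, 5-fluoro-2-methylphenyl in place of 4-fluoro-2-methoxyphenyl gives a 3.7-fold higher number from compound 3 to compound 4 (0.57 log units; beyond the scatter), and 5-fluoro-2-methylphenyl in place of phenyl gives a 5.6-fold higher number from compound 1 to compound 4 (0.75 log units; beyond the scatter). A fluorine on this aryl group therefore does not by itself hold the number level with compound 1: compound 3 and compound 4 both carry one, and only compound 4 stands clear of compound 1. Fluoro in place of hydrogen gives an at least 1.2-fold lower number from compound 2 to compound 4 (0.10 log units; that floor lies within the scatter), a step that is open-ended. Compound 2 stands at a limit: the limit of > 200000 nM in this assay, at which 1 of the 4 values shown sits.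

Compound 3 and compound 4 differ both in methoxy against methyl and in where the fluorine sits, so the two changes remain unseparated. Going by these compounds, how an amine or a carboxylic acid on this aryl group would read also remains open.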